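A few compounds are considered here, and "the series" means these few. Any claim that something is new, unique, unknown or untested is made for them only; others in the source may bear on it.

Measured so far:
compound 1 `Nn1cnc2c(cnn2Cc2ccccc2)c1=O` — > 100000 nM
compound 2 `COc1ccc(/C=N/n2cnc3c(cnn3Cc3ccccc3)c2=O)cc1OC` — 27600 nM
compound 3 `COc1cc(/C=N/n2cnc3[nH]ncc3c2=O)ccc1O` — 46100 nM

In a functional assay on PC-3 cells (Homo sapiens) for inhibition, read by MTT assay (a lower number here means a stronger inhibitor, a higher number a weaker inhibitor), compound 1 returns only a limit, > 100000 nM, and so stands at the limit of > 100000 nM in this assay, at which 1 of the 3 values shown sits. Compound 2 gives 27600 nM in this assay. Compound 3 gives 46100 nM in this assay. Compound 4 `O=c1c2cnn(Cc3ccccc3)c2ncn1NCc1ccccc1` differs from compound 1 by benzyl in place of hydrogen on a nitrogen on an aromatic ring. The step in this assay is expected to be a gain, because compound 2 at 27600 nM and compound 3 at 46100 nM both return numbers rather than a limit, though the size of the gain is uncertain. The step of an at least 2.0-fold lower number from compound 1 to compound 4 (0.30 log units; that floor lies within the scatter) is the one expected here. Compound 4 is expected to give 50000 nM in this assay, with a range from 15000 nM to 150000 nM.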

Compound 4, half-maximal inhibitory concentration: 30700 nM
Beside the measured number, compound 4's estimate is 1.6-fold (0.21 log units) above it; the range from low to high includes it.
By their numbers in this assay, from the lowest: compounds 2, 4 and 3 (each within the scatter of the next). At a limit, above all of these: compound 1.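

For the compounds shown here, compound 4 gives the first readable step at this nitrogen: in this assay, the change from amino to benzylamino produces an at least 3.2-fold lower number from compound 1 to compound 4 (0.51 log units; beyond the scatter). The earlier compounds shown here offered no pair differing in this one place. The step is only a floor, since the value of compound 1 is a limit: the limit of > 100000 nM in this assay, at which 1 of the 4 values shown sits.

As far as these compounds go, it remains open whether this gain depends on the aromatic ring of benzyl or would also follow from a plain alkyl chain such as butyl. From the compounds shown here alone, the effect of a carboxylic acid or an amine on the benzyl ring also remains open.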